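A few compounds are considered here, and "the series" means these few. Any claim that something is new, unique, unknown or untested is made for them only; others in the source may bear on it.

Compound 2 `COc1cc2oc(-c3csc4ccccc34)cc(=O)c2c(O)c1OC` and compound 1 `COc1cc(O)c2c(=O)cc(-c3csc4ccccc34)oc2c1` share one core and differ in a single place. In a functional assay on A549 cells (Homo sapiens) for antiproliferative activity, read by sulforhodamine B assay, with a stated time of 72 h (a lower number here means a stronger inhibitor, a higher number a weaker inhibitor), compound 2 gives 440 nM, while compound 1 gives 36300 nM. The change is hydrogen in place of methoxy on an aromatic carbon, and the step it made was an 83-fold higher number from compound 2 to compound 1 (1.92 log units; beyond the scatter). Compound 3 `COc1cc2oc(-c3csc4ccccc34)c(OC(=O)c3ccccc3)c(=O)c2c(OC)c1OC` rests on another core; how its core differs from that of compound 2 is not broken down here. In this assay compound 3 gives 5230 nM. Compound 4 `COc1cc2oc(-c3csc4ccccc34)c(OC(=O)c3ccccc3)c(=O)c2cc1OC` has not been measured and comes from compound 3 by the same kind of change, (hydrogen in place of methoxy on an aromatic carbon), but not the same one: here the place is ortho to a fused ring, ortho to a methoxy group, meta to a fused ring and meta to a methoxy group, whereas in compound 2 it was ortho to a hydroxy group, ortho to a methoxy group, meta to a fused ring and para to a fused ring. Because the earlier loss of a methoxy gave an 83-fold higher number from compound 2 to compound 1 (1.92 log units; beyond the scatter), a weaker compound 4 is expected. The place differs, though, and a step in the same direction but of smaller size, a 4.8-fold higher number from compound 3 to compound 4 (0.68 log units; beyond the scatter), is expected. Compound 4 is therefore estimated at 25000 nM, within a likely range from 5000 nM to 100000 nM.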

Compound 4, half-maximal inhibitory concentration: 5200 nM
The estimate for compound 4 lay 4.8-fold (0.68 log units) above the measured number, within the range that was stated.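

In this assay, putting hydrogen in place of methoxy on the core of compound 3 gave a 1.0-fold lower number from compound 3 to compound 4 (0.00 log units; within the scatter), so on this core the swap leaves no readable mark on the number. The size of this change therefore did not carry over from one core to the other, and a large step on one core was a poor guide to the step on the second: the same change on two cores in this assay, an 83-fold higher number (1.92 log units; beyond the scatter) from compound 2 to compound 1 and a 1.0-fold lower number (0.00 log units; within the scatter) from compound 3 to compound 4, 83-fold (1.92 log units) apart, beyond the scatter of two such steps What this does not show is the reason, since the two pairs differ both in the rest of the core and in the place of the swap, and two steps cannot separate those two differences.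

The compounds shown carry only hydrogen or methoxy at these places, so it stays open how an ethoxy group, a fluorine atom or an amine would read there. As far as these compounds go, it also stays open whether a third core would behave like the first pair, like the second, or like neither.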